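The source may hold more compounds than are shown below. What is called first, only, known or untested is meant among the compounds shown, and "the series" means these compounds.

Measured so far:
compound 1 `Fc1ccc(-c2csc(N/N=C/c3ccc(Cl)cc3Cl)n2)cc1`: 95.6%
compound 2 `Fc1ccc(-c2csc(N/N=C/c3cccs3)n2)cc1`: 92.4%

In a functional assay, read by spectrophotometry, with a stated time of 15 min, tested at 100 ug/mL (on this read-out higher numbers stand for a stronger effect at the one concentration tested and lower numbers for a weaker effect), compound 1 gives 95.6% and compound 2 gives 92.4%; these two values lie within the usual scatter of each other, so neither can be placed above the other on this read-out. Compound 3 `Clc1ccc(-c2csc(N/N=C/c3ccc(Cl)cc3Cl)n2)cc1` has not been measured. It differs from compound 1 by chloro in place of fluoro on an aromatic carbon. Among the compounds with values here, no measured pair shows this change, so no step is known for it. In this assay the expected step is a number 2.6 percentage points lower from compound 1 to compound 3 (within the scatter), not beyond the usual scatter in either direction. Compound 3 is therefore estimated at 93%, in the range 80% to 99%.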

Compound 3, a percentage reported as inhibition, at one concentration (the size of the read-out at that concentration, not a potency): 84.4%
Compound 3: middle estimate off by 8.6 percentage points, on the high side, and the stated range covers the measured number.
By their numbers in this assay, from the lowest: compounds 3, 2 and 1 (each within the scatter of the next, the first and the last beyond it).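

In this assay, chloro in place of fluoro on this six-membered aromatic ring gives a number 11.2 percentage points lower from compound 1 to compound 3 (beyond the scatter), so the read-out is sensitive to which of these two atoms sits at this position. The earlier compounds shown here both carry 4-fluorophenyl, so they could not show this. Nothing available explains the step.

The compounds shown carry only fluoro or chloro here, leaving open how an amine, a methoxy group or a longer chain would read out. Going by these compounds, whether the same swap gives a similar step on compound 2 also remains open.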